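The source may report more compounds than this note shows. Statements on the series, on what has been measured and on what is new or still open speak of the compounds shown alone.

Compound 2 `CC(C)OC(=O)NCCS(=O)(=O)NC(=O)c1ccc(Nc2nc(NC3(c4ccc(Cl)cc4)CC3)nc(OCC(F)(F)F)n2)cc1` stands at the lower of the two numbers measured in an ADME assay on microsomes from liver (Rattus norvegicus) for metabolic stability, with a stated time of 10 min; a higher number here means that more of the compound is left, a lower number that less of the compound is left: compound 2 gives 73%, while compound 1 `CC(C)C(=O)NCCS(=O)(=O)NC(=O)c1ccc(Nc2nc(NC3(c4ccc(Cl)cc4)CC3)nc(OCC(F)(F)F)n2)cc1` gives 84%. Among the compounds with values here, the one step between them, a number 11 percentage points lower from compound 1 to compound 2 (beyond the scatter), is the only measured change at this carbonyl carbon. Compound 3 `CNC(=O)NCCS(=O)(=O)NC(=O)c1ccc(Nc2nc(NC3(c4ccc(Cl)cc4)CC3)nc(OCC(F)(F)F)n2)cc1` takes the next step at the same place: methylamino in place of isopropoxy on a carbonyl carbon. Within the data shown here, no measured pair covers an exchange of this kind, so the step from compound 1 to compound 2 is the only guide, and it bears on it only loosely, since both groups exchanged in that step differ from methylamino. Compound 3 is therefore expected to stay close to compound 2 in this assay, with a step of a number 7 percentage points higher from compound 2 to compound 3 (within the scatter) that would not reach beyond the scatter. The estimate for compound 3 is 80%, within a range from 65% to 92%.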

Compound 3, percent of the compound remaining: 100%
Compound 3: middle estimate off by 20 percentage points, on the low side; the whole stated range lies below it.
By their numbers in this assay, from the lowest: compound 2; then compound 1; then compound 3.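

The earlier step showed only a fall at this carbonyl carbon, whereas this assay now shows that the same place can also move the number upward, with a number 27 percentage points higher from compound 2 to compound 3 (beyond the scatter) on exchanging isopropoxy for methylamino and a number 16 percentage points higher from compound 1 to compound 3 (beyond the scatter) on exchanging isopropyl for methylamino. The three groups now fall into a clear order, with all their steps beyond the scatter: methylamino gives the highest number, isopropyl the middle one and isopropoxy the lowest. Nothing shown here accounts for this order.

The compounds shown leave open whether the higher number belongs to methylamino alone or also extends to ethylamino or dimethylamino on the same carbonyl carbon. They also leave open where a smaller oxygen-linked group such as methoxy would fall relative to isopropoxy.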